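A Benzimidazol-2-yl Amine Tested for Cytotoxicity

A few compounds are considered here, and "the series" means these few. Any claim that something is new, unique, unknown or untested is made for them only; others in the source may bear on it.

Compound 1 `Cc1c(Cc2ccccc2)c(=O)oc2cc(OCC(O)CNc3ccccc3)ccc12`: > 100000 nM, a limit of the assay
Compound 2 `Cc1c(Cc2ccccc2)c(=O)oc2cc(OCC(O)CNCCCO)ccc12`: 53400 nM
Compound 3 `Cc1c(Cc2ccccc2)c(=O)oc2cc(OCC(O)CNCc3cccs3)ccc12`: 87300 nM

In an ADME assay on A549 cells (Homo sapiens) for cytotoxicity, read by CellTiter-Glo (on this read-out higher numbers stand for lower toxicity in this test and lower numbers for higher toxicity in this test), compound 1 reaches only a limit, > 100000 nM, a point at which (the limit of > 100000 nM in this assay, at which 1 of the 3 values shown sits). Compound 2 gives 53400 nM, the lower of the two plain numbers; the nearest is a 1.6-fold higher number from compound 2 to compound 3 (0.21 log units; within the scatter), with compound 3 at 87300 nM. Compound 4 `Cc1c(Cc2ccccc2)c(=O)oc2cc(OCC(O)CNc3nc4ccccc4[nH]3)ccc12` differs from compound 2 by 1H-benzimidazol-2-yl in place of 3-hydroxypropyl on an amine nitrogen. Within the data shown here, the steps that bear on this change are an at least 1.8-fold lower number from compound 1 to compound 2 (0.27 log units; that floor lies within the scatter) and an at least 1.1-fold lower number from compound 1 to compound 3 (0.05 log units; that floor lies within the scatter), both floors within the scatter, alongside a 1.6-fold higher number from compound 2 to compound 3 (0.21 log units; within the scatter). On that basis compound 4 is expected to move a 1.2-fold higher number from compound 2 to compound 4 (0.09 log units; within the scatter), no step beyond the scatter in this assay. Compound 4 is therefore estimated at 65000 nM, between 25000 nM and 150000 nM.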

Compound 4, half-maximal cytotoxic concentration: > 100000 nM
Compound 4 gave a limit, no number; the forecaster's own chance of this, stated with the estimate: 30%; middle value at least 1.5-fold (0.18 log units) from the limit.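

In this assay compound 4 gives > 100000 nM, a limit and not a number, so this position carries a fused aromatic group on the amine nitrogen without yielding a measurable value. The steps, an at least 1.8-fold higher number from compound 2 to compound 4 (0.27 log units; that floor lies within the scatter) and an at least 1.1-fold higher number from compound 3 to compound 4 (0.05 log units; that floor lies within the scatter), give floors only, and the step from compound 1 cannot be read. Two of the compounds now rest at the ceiling: the limit of > 100000 nM in this assay, at which 2 of the 4 values shown sit.

From the compounds shown here alone, what a plain imidazol-2-yl or a longer hydroxyalkyl chain on that amine nitrogen would give remains open. So does how far compound 1 and compound 4 actually lie beyond the limit.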